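Extending a Carbamate Chain by One Methyl

This account rests on a few compounds, and the source may have more. Where it says the series, first, only, none or still open, it means among the compounds named here.

Compound 1 `CCCOC(=O)Nc1ccc([Se]C#N)cc1`: 47400 nM
Compound 2 `O=C(Nc1ccc([Se][Se]c2ccc(NC(=O)OCc3ccccc3)cc2)cc1)OCc1ccccc1`: 33500 nM
Compound 3 `N#C[Se]c1ccc(NC(=O)Oc2ccc(Cl)cc2)cc1`: 18700 nM

In a functional assay on PC-3 cells (Homo sapiens) for cytotoxicity, read by MTT assay, with a stated time of 72 h (on this read-out lower numbers stand for stronger inhibition of growth and higher numbers for weaker inhibition of growth), compound 1 gives the highest of the three numbers, though compound 2 lies within the scatter of it, so no order between those two can be read. Compound 3 gives a lower number, and that gap lies beyond the scatter. Compound 4 `CCCCOC(=O)Nc1ccc([Se]C#N)cc1` differs from compound 1 by methyl in place of hydrogen on a saturated chain carbon, three bonds along the chain from an oxygen next to a carbonyl group; read one bond further out, the change is propyl to butyl. Among the compounds with values here, no step between measured compounds mirrors it, and the expectation rests on the smallness of the change. Compound 4 is therefore expected to sit close to compound 1, with a step of a 1.3-fold lower number from compound 1 to compound 4 (0.12 log units; within the scatter) that stays within the scatter. Compound 4 is estimated at 36000 nM, between 15000 nM and 85000 nM.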

Compound 4, concentration for total growth inhibition: 40800 nM
Beside the measured number, compound 4's estimate is 1.1-fold (0.05 log units) below it; low and high end bracket the measured number.
By their numbers in this assay, from the lowest: compounds 3, 2, 4 and 1 (each within the scatter of the next, the first and the last beyond it).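

Going from propyl to butyl gives a 1.2-fold lower number from compound 1 to compound 4 (0.07 log units; within the scatter) in this assay and so stays within the scatter. At this saturated chain carbon, methyl in place of hydrogen therefore leaves no change that this read-out can resolve. Within the data shown here, none of the earlier compounds isolated this position as a single step.

From the compounds shown here alone, whether a longer chain, a branched chain or a terminal amine at the same place would also stay within the scatter remains open. Nothing measured here offers an explanation for this result.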